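The source may hold more compounds than are shown below. What is called first, only, known or untested is meant among the compounds shown, and "the series" means these compounds.

Of the compounds shown here, two have been measured so far, compound 1 `CN1CCC(c2c[nH]c3ccc(NC(=O)c4cccs4)nc23)CC1` and compound 2 `CN1CCC(c2c[nH]c3ccc(NC(=O)c4ccncc4)nc23)CC1`. They share one core and differ only in the aromatic ring attached to a carbonyl carbon. In an assay for binding affinity to 5-hydroxytryptamine receptor 1B (Homo sapiens), read by radioligand binding (on this read-out lower numbers stand for stronger inhibition and higher numbers for weaker inhibition), compound 1 gives 390 nM, and compound 2 gives 330 nM. Among the measured compounds shown here, the one measured step, a 1.2-fold lower number from compound 1 to compound 2 (0.07 log units; within the scatter), shows that swapping one aromatic ring for another at that carbonyl carbon left the number essentially where it was. Compound 2 has the smaller of the two numbers, but since its gap to compound 1 lies within the scatter, the two compounds cannot be separated on this evidence.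

Compound 3 `CN1CCC(c2c[nH]c3ccc(NC(=O)Nc4ccc(F)cc4)nc23)CC1` has not yet been measured. It differs from compound 2 in one place: (4-fluorophenyl)amino in place of pyridin-4-yl on a carbonyl carbon. The earlier step bears on this change only loosely, since it exchanged one ring for another, whereas here a ring gives way to an amino-linked ring and a hydrogen-bond donor enters where a hydrogen-bond acceptor leaves. Because a 1.2-fold lower number from compound 1 to compound 2 (0.07 log units; within the scatter) was small, a modest step at most is expected here, in no firm direction. Compound 3 is therefore estimated to give 300 nM, with a range from 100 nM to 1000 nM. The implied step, a 1.1-fold lower number from compound 2 to compound 3 (0.04 log units; within the scatter), is expected to stay within the scatter.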

Compound 3, inhibition constant: 3.2 nM
The estimate for compound 3 lay 94-fold (1.97 log units) above the measured number; the measured number lies below the stated range.
By their numbers in this assay, from the lowest: compound 3; then compounds 2 and 1 (each within the scatter of the next).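

Unlike the ring-for-ring exchange, which gave a 1.2-fold lower number from compound 1 to compound 2 (0.07 log units; within the scatter), the place on the carbonyl carbon proves highly sensitive to what is attached once (4-fluorophenyl)amino enters. In this assay, replacing pyridin-4-yl with this group gives a 100-fold lower number from compound 2 to compound 3 (2.01 log units; beyond the scatter), and replacing thiophen-2-yl with it gives a 120-fold lower number from compound 1 to compound 3 (2.09 log units; beyond the scatter), so the large drop appears against both earlier rings. This single change adds a hydrogen-bond donor, an amino nitrogen and a fluorine together, and no measurement here explains the drop or assigns it to any one of these features.

The compounds shown leave open how much of the drop belongs to the amino nitrogen and how much to the fluorine, which a plain phenylamino group or a 4-fluorophenyl ring attached directly to the carbonyl carbon could help separate. They also leave open whether an aromatic ring is needed in the entering group at all, a question that a non-aromatic group such as cyclohexylamino could address.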